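This account rests on a few compounds, and the source may have more. Where it says the series, first, only, none or still open, it means among the compounds named here.

Of the compounds shown here, two that share one core have so far been measured in a functional assay on HeLa cells (Homo sapiens) for cytotoxicity, read by MTT assay, with a stated time of 2 days; a higher number here means that more compound is tolerated, a lower number that less compound is tolerated. Compound 1 `CC(=O)c1cc(-c2ccc(F)cc2)cc2cc(-c3ccc(F)cc3)[nH]c12` gives 13800 nM. Compound 2 `CC(=O)c1cc(/C=C/c2ccccc2)cc2cc(-c3ccccc3)[nH]c12` gives 30800 nM, the higher of the two numbers, and its gap to compound 1 lies beyond the usual scatter. Compound 3 `CC(=O)c1cc(/C=C/c2ccccc2)cc2cc(-c3ccc(F)cc3)[nH]c12` differs from compound 2 by fluoro in place of hydrogen on an aromatic carbon. Among the compounds with values here, no measured pair isolates this change, so its effect is unknown here. Compound 3 is therefore expected to stay near compound 2, with an expected step of a 1.2-fold lower number from compound 2 to compound 3 (0.09 log units; within the scatter) that lies within the usual scatter. In this assay compound 3 is estimated at 25000 nM, ranging from 12000 nM to 50000 nM.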

Compound 3, concentration lethal to 50% of the cells: 16100 nM
Compound 3: the middle estimate sits 1.6-fold (0.19 log units) above what was measured; low and high end bracket the measured number.
By their numbers in this assay, from the lowest: compounds 1, 3 and 2 (each within the scatter of the next, the first and the last beyond it).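

In this assay, within the data shown here, the first pair to isolate fluoro in place of hydrogen on this aromatic carbon, phenyl to 4-fluorophenyl, gives a 1.9-fold lower number from compound 2 to compound 3 (0.28 log units; within the scatter), a step that cannot be told apart from the scatter. Placing 2-phenylethenyl in place of 4-fluorophenyl on an aromatic carbon likewise gives a 1.2-fold higher number from compound 1 to compound 3 (0.07 log units; within the scatter), so this change also shows no readable step here. Nothing available here explains either step. As far as these compounds go, whether chloro, an amine or a carboxylic acid at the same place would give a step beyond the scatter remains open.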